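This account rests on a few compounds, and the source may have more. Where it says the series, first, only, none or still open, it means among the compounds named here.

Within the data shown here, in an ADME assay on HEK293 cells (Homo sapiens) for cytotoxicity, read by MTT assay, with a stated time of 72 h (a lower number here means a stronger inhibitor, a higher number a weaker inhibitor), compound 3 (`COc1ccc(C2=C(c3cc(OC)c(OC)c(OC)c3)C(=O)CC2O)cc1`) gives 10 ug/mL, the only actual number so far. Compound 1 (`COc1ccc(C2=C(c3cc(OC)c(OC)c(OC)c3)C(=O)CC2O)cc1O`) reads > 100 ug/mL, which is a limit of the assay. Compound 2 (`COc1cc(C2=C(c3ccc(OCC(=O)O)cc3)C(O)CC2=O)cc(OC)c1OC`) reads > 100 ug/mL, also a limit. Compound 4 (`CCOC(=O)COc1ccc(C2=C(c3cc(OC)c(OC)c(OC)c3)C(=O)CC2O)cc1`) differs from compound 3 by ethoxycarbonyl in place of hydrogen on a saturated chain carbon bound to an oxygen on an aromatic ring, with ethoxycarbonyl in place of hydrogen on a saturated chain carbon bound to an oxygen on an aromatic ring. Among the measured compounds shown here, the one measured step at that place, hydrogen in place of carboxy, is an at least 10-fold lower number from compound 2 to compound 3 (1.00 log units; beyond the scatter). The other, an at least 10-fold lower number from compound 1 to compound 3 (1.00 log units; beyond the scatter), is a change at another place and bears only weakly. Ethoxycarbonyl is not carboxy, so that step gives a direction rather than a size in this assay. A modest move towards weaker inhibition is expected, a 2.0-fold higher number from compound 3 to compound 4 (0.30 log units; within the scatter). Compound 4 is estimated at 20 ug/mL, with an expected range of 6 ug/mL to 80 ug/mL.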

Compound 4, half-maximal inhibitory concentration: > 100 ug/mL
Compound 4 was reported as a limit; the forecaster's own chance of this, stated with the estimate: 20%; middle value at least 5.0-fold (0.69 log units) away from the limit.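

In this assay, ethoxycarbonyl on this saturated chain carbon gives an at least 10-fold higher number from compound 3 to compound 4 (1.00 log units; beyond the scatter), so a carboxy group is not required at this place for the higher number. The ester and the carboxy compound cannot be ranked against each other, as the step between compound 2 and compound 4 cannot be read: the limit of > 100 ug/mL in this assay, at which 3 of the 4 values shown sit.

Going by these compounds, the full size of the change from hydrogen to ethoxycarbonyl stays open. Also open, on these data alone, is whether an amine or a simple longer chain at this place would keep a number close to that of compound 3, 10 ug/mL.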